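A few compounds are considered here, and "the series" means these few. Any claim that something is new, unique, unknown or untested is made for them only; others in the source may bear on it.

Measured compounds:
- compound 1, `Cc1ccc(C(C2Cc3ccccc3O2)n2cncn2)cc1`, 96.8%
- compound 2, `c1ccc(C(C2Cc3ccccc3O2)n2cnnn2)cc1`, 35%
- compound 3, `Clc1ccc(C(C2Cc3ccccc3O2)n2cnnn2)cc1`, 90.3%

In an assay for inhibition of Aromatase (Homo sapiens), tested at 20 uM (on this read-out lower numbers stand for less inhibition and higher numbers for more inhibition at the one concentration tested (going by the name of the read-out)), compound 3 stands second highest of the three numbers; its value lies within the scatter of compound 1 and beyond the scatter above compound 2. Compound 4, `Cc1ccc(C(C2Cc3ccccc3O2)n2cnnn2)cc1`, differs from compound 3 by methyl in place of chloro on an aromatic carbon. Among the compounds with values here, no measured step covers methyl against chloro. Within the data shown here, the only step near it is a number 55.3 percentage points higher from compound 2 to compound 3 (beyond the scatter), which shows that a group on that aromatic carbon, compared with hydrogen, goes with a large rise. Compound 1, which carries a methyl at that place on another core, shows a value within the scatter of compound 3. Compound 4 is therefore expected to stay near compound 3, with a small step of a number 6.3 percentage points lower from compound 3 to compound 4 (within the scatter). The estimate for compound 4 is 84%, within 62% to 97%.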

Compound 4, a percentage reported as inhibition, at one concentration (the size of the read-out at that concentration, not a potency): 67.2%
Beside the measured number, compound 4's estimate is 16.8 percentage points above it; the range from low to high includes it.
By their numbers in this assay, from the lowest: compound 2; then compound 4; then compounds 3 and 1 (each within the scatter of the next).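

In this assay, the substituent at this place matters beyond merely replacing hydrogen: methyl in place of chloro gives a number 23.1 percentage points lower from compound 3 to compound 4 (beyond the scatter), so the two groups are not interchangeable here. Methyl in place of hydrogen still gives a number 32.2 percentage points higher from compound 2 to compound 4 (beyond the scatter), so methyl keeps part of the gain. With 4-methylphenyl held constant, 1H-tetrazol-1-yl in place of 1H-1,2,4-triazol-1-yl gives a number 29.6 percentage points lower from compound 1 to compound 4 (beyond the scatter), showing that the azole also counts. On these data alone, whether a methoxy group or an amine at this place would follow chloro or methyl remains open. Nothing shown here explains these differences.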